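A few compounds are considered here, and "the series" means these few. Any claim that something is new, unique, unknown or untested is made for them only; others in the source may bear on it.

In an ADME assay on microsomes from liver (Rattus norvegicus) for metabolic stability, read by LC-MS, in the presence of a further agent that is not named here (a higher number here means faster removal of the compound, a lower number slower removal), compound 1 (`Cc1ncc(C)n2nc(-c3ccc4nc(-c5ccco5)[nH]c4c3)nc12`) gives 26.3 mL.min-1.g-1 and compound 2 (`Cc1ncc(C)n2nc(-c3ccn4cc(-c5ccccc5Br)nc4n3)nc12`) gives 1.8 mL.min-1.g-1 as its number. Compound 2 thus holds the lower of the two numbers, by a gap well beyond the scatter of repeat measurements, so it is removed the more slowly. The two compounds differ in more than one place, so that gap cannot be pinned on any single group.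

Compound 3 (`COc1ccccc1-c1cn2ccc(-c3nc4c(C)ncc(C)n4n3)nc2n1`) has not yet been measured. It differs from compound 2 by one swap, methoxy in place of bromo on an aromatic carbon. Among the measured compounds shown here, no measured pair shows this swap, so the guide is thin. With compound 2 at 1.8 mL.min-1.g-1 and compound 1 at 26.3 mL.min-1.g-1 there is more room for compound 3 to rise than to fall. The expected step is a small rise, estimated as a 2.2-fold higher number from compound 2 to compound 3 (0.35 log units; beyond the scatter) in this assay once measured. The estimated value for compound 3 is 4 mL.min-1.g-1 with a range from 1.5 mL.min-1.g-1 to 12 mL.min-1.g-1 as the expected span.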

Compound 3, intrinsic clearance in microsomes: 9.1 mL.min-1.g-1
Compound 3: middle estimate off by 2.3-fold (0.36 log units), on the low side; measured number inside the range.
By their numbers in this assay, from the lowest: compound 2; then compound 3; then compound 1.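

In this assay, among the compounds shown here, the change from 2-bromophenyl to 2-methoxyphenyl gives a 5.1-fold higher number from compound 2 to compound 3 (0.70 log units; beyond the scatter), the first step here that can be tied to a single place in the molecule. The group on this aromatic carbon, ortho to a large group, therefore matters: this one swap moves the number beyond the usual scatter, with bromo giving the slower removal of the pair. No measured information here explains the step.

From the compounds shown here alone, it remains open whether the rise follows from the arrival of methoxy or from the loss of bromo, and whether the same swap would act alike on another core. A chloro, fluoro, hydroxyl or ethoxy group at this place would show how the number changes across other groups.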